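The source may hold more compounds than are shown below. What is called first, only, known or untested is meant among the compounds shown, and "the series" means these compounds.

Three compounds of the series have values in a physicochemical assay for lipophilicity, at pH 7.4; a lower number here means a more polar compound, a higher number a more lipophilic compound. Compound 1 (`CCc1ccc(N(CC2CC2)S(=O)(=O)c2ccc3c(c2)C(=O)CC(C2CCOCC2)O3)cc1`) gives 3.77 and compound 3 (`CC(C)CN(c1ccc(N(C)C)cc1)S(=O)(=O)c1ccc2c(c1)C(=O)CC(C1CCOCC1)O2`) gives 3.6, two numbers within the usual scatter of each other. Compound 2 (`CCc1ccc(N(CC(C)C)S(=O)(=O)c2ccc3c(c2)C(=O)CC(C2CCN(C(=O)C4CCCC4)CC2)O3)cc1`) gives 5.13, the highest of the three and beyond the scatter from both of the others.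

Compound 4 (`CCc1ccc(N(CC(C)C)S(=O)(=O)c2ccc3c(c2)C(=O)CC(C2CCNCC2)O3)cc1`) has not yet been measured. It differs from compound 2 in one place: hydrogen in place of cyclopentylcarbonyl on an amine nitrogen in a ring. This puts hydrogen in place of cyclopentylcarbonyl on an amine nitrogen in a ring.

Going by the values given here, no measured pair isolates this change, so its size can only be estimated. A large fall in this assay, well beyond the scatter, is expected. Among the compounds with values here, the only guide is indirect: compound 1 at 3.77 and compound 3 at 3.6 also lack cyclopentylcarbonyl, although they differ from compound 2 elsewhere too. The estimated step is a number 2.53 log units lower from compound 2 to compound 4 (beyond the scatter). The expected value for compound 4 is 2.6, with an estimated range of 1.9 to 3.4.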

Compound 4, distribution coefficient: 2.21
Compound 4: middle estimate off by 0.39 log units, on the high side; measured number inside the range.
By their numbers in this assay, from the lowest: compound 4; then compounds 3 and 1 (each within the scatter of the next); then compound 2.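

In this assay, going by these compounds alone, hydrogen in place of cyclopentylcarbonyl on the amine nitrogen in a ring gives a number 2.92 log units lower from compound 2 to compound 4 (beyond the scatter), the first step that isolates a single change. The substituent on this nitrogen alone therefore moves the read-out well beyond the scatter, so this place has a large bearing on the number. Nothing measured here bears on why the step has this size.

The pair gives only two end points and cannot separate the loss of the carbonyl from the loss of the five-membered ring of carbon only. Where an acetyl group, a methyl group or a smaller or larger acyl ring on this nitrogen would fall remains open, as does whether the step holds with other groups on the shared core.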